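The source may report more compounds than this note shows. Statements on the series, on what has been measured and on what is new or still open speak of the compounds shown alone.

Measured compounds:
Compound 1, `CC[C@@H]1C(=O)N(C)c2cnc(-n3ccc4cc(F)ccc43)nc2N1C1CCCC1`: 46500 nM
Compound 2, `CC[C@@H]1C(=O)N(C)c2cnc(Nc3ccc(S(=O)(=O)NCCO)cc3)nc2N1C1CCCC1`: 2100 nM
Compound 3, `CCC1C(=O)N(C)c2cnc(-n3ccc4cc(C(=O)NC(C)C)ccc43)nc2N1c1ccn(C)n1`: 12200 nM

These three were tested in a functional assay on NCI-H1975 cells (Homo sapiens) for antiproliferative activity, read by CCK-8 assay, with a stated time of 72 h; on this read-out higher numbers stand for weaker inhibition of growth and lower numbers for stronger inhibition of growth. Compound 2 gives the lowest number of the three, and its gap to compound 3 and to compound 1 both lie beyond the usual scatter of this kind of measurement. Compound 4, `CCCCNS(=O)(=O)c1ccc(Nc2ncc3c(n2)N(C2CCCC2)[C@H](CC)C(=O)N3C)cc1`, has not yet been measured. It differs from compound 2 in one place: ethyl in place of hydroxy on a saturated chain carbon, two bonds along the chain from a sulfonamide nitrogen. For the measured compounds named here, no pair of measured compounds differs in a single place, so there is no measured step to guide this change. A step of no more than the scatter is expected in this assay, in either direction. Compound 4 is expected to give 2600 nM, within 900 nM to 8000 nM. The expected step from compound 2 to compound 4 is a 1.2-fold higher number from compound 2 to compound 4 (0.09 log units; within the scatter).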

Compound 4, concentration for 50% growth inhibition: 1610 nM
Compound 4: middle estimate off by 1.6-fold (0.21 log units), on the high side; the measured number falls inside the stated range.
By their numbers in this assay, from the lowest: compounds 4 and 2 (each within the scatter of the next); then compound 3; then compound 1.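

In this assay the change from 2-hydroxyethyl to butyl on the sulfonamide nitrogen gives a 1.3-fold lower number from compound 2 to compound 4 (0.12 log units; within the scatter) and so stays within the scatter. This first single-place comparison shows that growth inhibition at this level does not depend on the hydroxy group, and that this chain position accepts a plain butyl chain in its place. No evidence is available on the reason for this. As far as these compounds go, how an amine or a carboxylic acid at the end of this chain would compare remains open, as does a longer chain.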